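The source may report more compounds than this note shows. Statements on the series, on what has been measured and on what is new or still open speak of the compounds shown alone.

Compound 1 `NCC(=O)NCC(=O)Nc1ccc([N+](=O)[O-])cc1C(=O)c1ccccc1Cl` gives 63.9 mg/kg
Compound 2 `CN(C(=O)CNC(=O)CN)c1ccc([N+](=O)[O-])cc1C(=O)c1ccccc1` gives 2.94 mg/kg
Compound 3 `CC(=O)NCC(=O)N(C)c1ccc(Cl)cc1C(=O)c1ccccc1Cl` gives 58 mg/kg

With a functional assay on the whole organism with Mus musculus as the target, in the rotarod test (on this read-out higher numbers stand for an effect only at larger amounts of compound and lower numbers for an effect already at smaller amounts), as the common read-out, compound 3 lies within the scatter of compound 1, and both lie far above compound 2 on the numbers. Compound 2 at 2.94 mg/kg shows how low the numbers reach in this small set, but it differs from compound 3 in more than one place.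

Compound 4 `CCCCCCC(=O)NCC(=O)N(C)c1ccc(Cl)cc1C(=O)c1ccccc1Cl` keeps everything in compound 3 except one change: pentyl in place of hydrogen on a saturated chain carbon bound to a carbonyl carbon in the form of pentyl in place of hydrogen on a saturated chain carbon bound to a carbonyl carbon. The same difference also reads acetyl to hexylcarbonyl.

For the measured compounds named here, no two measured compounds differ in one place only, so nothing measured so far shows what this change does. The expectation therefore starts from compound 3 at 58 mg/kg and allows wide uncertainty on both sides. The estimated change is a 1.4-fold higher number from compound 3 to compound 4 (0.14 log units; within the scatter) and so a small move toward a higher number, one that is not expected to clear the scatter. In this assay compound 4 is estimated at 80 mg/kg with an expected range from 25 mg/kg to 300 mg/kg as its bounds.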

Compound 4, dose for half-maximal effect: 70 mg/kg
Compound 4: middle estimate off by 1.1-fold (0.06 log units), on the high side, within the range that was stated.
By their numbers in this assay, from the lowest: compound 2; then compounds 3, 1 and 4 (each within the scatter of the next).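

In this assay, for the compounds shown here, putting pentyl in place of hydrogen on a saturated chain carbon bound to a carbonyl carbon gives a 1.2-fold higher number from compound 3 to compound 4 (0.08 log units; within the scatter), the first step in this set that can be read at a single place. The earlier compounds shown here, none of them one change apart, could not show what this place allows; now the acetyl of compound 3 and the hexylcarbonyl of compound 4 prove indistinguishable on this read-out, their numbers lying within the scatter of each other even though the chain grows from methyl to hexyl. No measurement given here bears on why these two compounds lie so close.

On these data alone, whether a longer chain, a carboxylic acid or a hydroxyl at the end of this chain would also stay within the scatter of compound 3 remains open, since a single pentyl marks only one point at this place. Also open is what goes with the much lower number of compound 2 at 2.94 mg/kg, as that compound differs from compound 3 in more than one place and no single change can be picked out from the compounds shown.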